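Aryl variation on the core of compound 1

The source may report more compounds than this note shows. Statements on the series, on what has been measured and on what is new or still open speak of the compounds shown alone.

Compound 1 `O=C1C(=Cc2ccc(Cl)cc2)C(=O)N(c2ccc(Cl)cc2)N1c1ccc(Cl)cc1` stands highest of the three measured values in a functional assay on SMMC-7721 cells (Homo sapiens) for cytotoxicity, read by MTT assay, with a stated time of 72 h (on this read-out lower numbers stand for stronger inhibition and higher numbers for weaker inhibition), where compound 1 gives 30900 nM. Compound 2 `O=C1C(=Cc2ccc(Br)cc2)C(=O)N(c2ccc(Cl)cc2)N1c1ccc(Cl)cc1` gives 16600 nM in this assay, and compound 3 `COc1ccccc1C=C1C(=O)N(c2ccc(Cl)cc2)N(c2ccc(Cl)cc2)C1=O` gives 25800 nM. Every measured step is within the scatter: a 1.9-fold lower number from compound 1 to compound 2 (0.27 log units; within the scatter), a 1.2-fold lower number from compound 1 to compound 3 (0.08 log units; within the scatter) and a 1.6-fold higher number from compound 2 to compound 3 (0.19 log units; within the scatter). Compound 4 `O=C1C(=Cc2ccc(F)cc2F)C(=O)N(c2ccc(Cl)cc2)N1c1ccc(Cl)cc1` differs from compound 1 by 2,4-difluorophenyl in place of 4-chlorophenyl on a double-bonded chain carbon bound to a double-bonded ring carbon. The change at the same place in compound 3 and the halogen swap in compound 2 both left the number within the scatter, so for compound 4 no step beyond the scatter is expected in this assay, and the estimated step is a 1.2-fold lower number from compound 1 to compound 4 (0.09 log units; within the scatter). The value expected for compound 4 is 25000 nM, with a range from 10000 nM to 60000 nM.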

Compound 4, half-maximal inhibitory concentration: 35800 nM
For compound 4 the middle estimate is 1.4-fold (0.16 log units) below the measured one, and the stated range covers the measured number.
By their numbers in this assay, from the lowest: compounds 2, 3, 1 and 4 (each within the scatter of the next, the first and the last beyond it).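

In this assay the exchange of 4-chlorophenyl for 2,4-difluorophenyl gives a 1.2-fold higher number from compound 1 to compound 4 (0.06 log units; within the scatter) and the exchange of 2-methoxyphenyl for it gives a 1.4-fold higher number from compound 3 to compound 4 (0.14 log units; within the scatter) on the same chain carbon. Among these compounds, the exchange of 4-bromophenyl for 2,4-difluorophenyl gives a 2.2-fold higher number from compound 2 to compound 4 (0.33 log units; beyond the scatter) as the first step beyond the scatter at this position, a modest one, so the aryl groups here no longer all read alike. Nothing at hand accounts for that gap. On these data alone, whether an amine or a carboxylic acid on the aryl ring at this place would move the number further remains open.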